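The compounds below may be only part of what the source reports. "The series", "measured", "known", "first", "only" and "open" are said of these compounds alone.

Compound 1 `COc1cc2ncnc(N3CCC(CN4CCN(c5ccccc5)CC4)C3)c2cc1OC`: 251 nM
Compound 2 `COc1cc2ncnc(N3CCC(CN4CCN(c5cccc(C(F)(F)F)c5)CC4)C3)c2cc1OC`: 229 nM

Among the compounds with values here, in an assay on membranes from CHO-K1 cells for displacement of a labelled ligand from 5-hydroxytryptamine receptor 7 (Homo sapiens), read by scintillation counting (a higher number here means a weaker inhibitor, a lower number a stronger inhibitor), compound 2 shows the lowest of the two numbers, but its only neighbour is compound 1, and the step of a 1.1-fold lower number from compound 1 to compound 2 (0.04 log units; within the scatter) lies within the scatter, so the two cannot be ranked. Compound 3 `COc1cc2ncnc(N3CCC(CN4CCN(c5ccccn5)CC4)C3)c2cc1OC` differs from compound 2 by pyridin-2-yl in place of 3-(trifluoromethyl)phenyl on an amine nitrogen in a ring. Within the data shown here, no measured step swaps one aromatic ring for another at this position; the only step seen, a 1.1-fold lower number from compound 1 to compound 2 (0.04 log units; within the scatter), alters a group on that ring and changed little. Accordingly, a modest step is expected, a 1.5-fold higher number from compound 2 to compound 3 (0.18 log units; within the scatter). Compound 3 is expected to give about 350 nM in this assay, with a range from 120 nM to 1000 nM.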

Compound 3, inhibition constant: 282 nM
For compound 3 the middle estimate is 1.2-fold (0.09 log units) above the measured one; measured number inside the range.
By their numbers in this assay, from the lowest: compounds 2, 1 and 3 (each within the scatter of the next).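

In this assay, the whole aromatic ring on the amine nitrogen is exchanged, giving a 1.2-fold higher number from compound 2 to compound 3 (0.09 log units; within the scatter) and a 1.1-fold higher number from compound 1 to compound 3 (0.05 log units; within the scatter). So far, then, this position holds a ring containing nitrogen, pyridin-2-yl, with no step beyond the scatter, just as it holds phenyl and 3-(trifluoromethyl)phenyl. No measurement at hand offers a reason for this result. Going by these compounds, all three compounds carry an aromatic ring here, so the effect of a cyclohexyl ring or an open carbon chain on this nitrogen remains open.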